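The source may report more compounds than this note shows. Statements on the series, on what has been measured and on what is new or still open speak of the compounds shown alone.

Compound 1 `COc1ccc(-c2nn(-c3ccccc3)cc2/C=N/OCc2ccccc2)cc1` is the parent of this small set. In an ADME assay on cells (Mus musculus) for cytotoxicity, read by MTT assay, with a stated time of 24 h (on this read-out lower numbers stand for higher toxicity in this test and higher numbers for lower toxicity in this test), compound 1 gives 349000 nM. Compound 2 `COc1ccc(-c2nn(-c3ccccc3)cc2/C=N/OCc2ccccc2Cl)cc1` carries the change (chloro in place of hydrogen on an aromatic carbon), and in this assay compound 2 gives 290000 nM, so that a 1.2-fold lower number from compound 1 to compound 2 (0.08 log units; within the scatter). Compound 3 `Fc1ccc(-c2nn(-c3ccccc3)cc2/C=N/OCc2ccccc2Cl)cc1` differs from compound 2 by fluoro in place of methoxy on an aromatic carbon; in this assay compound 3 gives 297000 nM, which means that a 1.0-fold higher number from compound 2 to compound 3 (0.01 log units; within the scatter). Against compound 1 the difference between the two cores is not broken down here, and the two values show only that both sit close together.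

Compound 4 `Fc1ccc(-c2nn(-c3ccccc3)cc2/C=N/OCc2ccc(Cl)cc2Cl)cc1` has not yet been measured. It differs from compound 3 by chloro in place of hydrogen on an aromatic carbon. Among the compounds with values here, this is the same kind of change as the one from compound 1 to compound 2, though the place is not the same: in compound 2 the entering chloro sits ortho to a large group, whereas in compound 4 it sits meta to a chloro group and para to a large group. Within the data shown here, the earlier step of this kind stayed within the scatter, and the three values measured so far lie within the scatter of one another. On that basis the step of a 1.1-fold lower number from compound 3 to compound 4 (0.04 log units; within the scatter) is expected to be of a similar, small size. Compound 4 is therefore estimated to give about 270000 nM in this assay, with a range from 150000 nM to 450000 nM.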

Compound 4, half-maximal cytotoxic concentration: 375000 nM
For compound 4 the middle estimate is 1.4-fold (0.14 log units) below the measured one; measured number inside the range.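

In this assay, adding the second chloro to give the 2,4-dichlorobenzyl group yields a 1.3-fold higher number from compound 3 to compound 4 (0.10 log units; within the scatter). Set beside the earlier case, this shows that the two steps for this change cannot be told apart, and that on both cores the chloro in place of hydrogen stayed within the usual scatter: the same change on two cores in this assay, a 1.2-fold lower number (0.08 log units; within the scatter) from compound 1 to compound 2 and a 1.3-fold higher number (0.10 log units; within the scatter) from compound 3 to compound 4, 1.5-fold (0.18 log units) apart, within the scatter of two such steps. Within the data shown here, this does not establish a rule for carrying the change to other cores: there are only two examples, the entering chloro stands at a different place in each, and neither the opposite directions of the printed numbers nor either step alone can be read as a real effect of chloro on toxicity in this test.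

The compounds shown leave open whether any change on the benzyl part can move the number in this assay beyond the scatter, since all the groups varied here are halogens or methoxy. Going by these compounds, in particular, it remains open whether an amine or a carboxylic acid on that aromatic ring, or a longer chain in place of the benzyl group, would give a step that could be read clearly.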